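This account rests on a few compounds, and the source may have more. Where it says the series, first, only, none or still open, it means among the compounds named here.

Working notes on the series. Of the compounds shown here, three have been measured, all built on the same core: compound 1 `O=C(O)/C(S)=C/c1ccc(Cl)cc1`, compound 2 `O=C(O)/C(S)=C/c1ccccc1Cl` and compound 3 `O=C(O)/C(S)=C/c1cccc(Br)c1`. In an assay on isolated protein for inhibition of Calpain-1 catalytic subunit (Sus scrofa) (a higher number here means a weaker inhibitor, a lower number a stronger inhibitor), compound 1 gives 15000 nM, compound 2 gives 20700 nM and compound 3 gives 8400 nM. Compound 3 stands at the lowest of the three numbers. Its nearest neighbour is compound 1, whose number lies within the scatter of repeated measurements, so the two cannot be separated; compound 2 lies furthest away, with a higher number that sits beyond the scatter.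

Compound 4 `O=C(O)/C(S)=C/c1cccc(I)c1` has not yet been measured in this assay. It differs from compound 3 in one place: iodo in place of bromo on an aromatic carbon. For the measured compounds named here, no step between any two measured compounds in this set involves such an exchange, so there is nothing measured to lean on for its size. The change is small in what it adds and removes, and the expectation is a step from compound 3 to compound 4 of a 1.3-fold lower number from compound 3 to compound 4 (0.11 log units; within the scatter) in this assay, that is, no change beyond the scatter, with a slight lean toward a lower number. Compound 4 is therefore expected to give about 6500 nM in this assay, with a plausible range from 2500 nM to 16000 nM.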

Compound 4, half-maximal inhibitory concentration: 23900 nM
Compound 4: middle estimate off by 3.7-fold (0.57 log units), on the low side, and the stated range ends below it.
By their numbers in this assay, from the lowest: compounds 3, 1, 2 and 4 (each within the scatter of the next, the first and the last beyond it).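

In this assay, replacing bromo with iodo on an aromatic carbon, meta to a group of 6 heavy atoms, gives a 2.8-fold higher number from compound 3 to compound 4 (0.45 log units; beyond the scatter), a modest step but one beyond the scatter. For the compounds shown here, this is the first step that can be read between two compounds differing in one place, and it shows that the outcome at this position depends on which of these two halogens is present, even though the count of heavy atoms, hydrogen-bond donors, hydrogen-bond acceptors and net charge stays the same. No measurement to hand accounts for the step.

On these data alone, with a single step at this position, it remains open whether a fluoro, methyl, methoxy or nitrile group there would give a number closer to that of compound 3 or of compound 4. Also open, as far as these compounds go, is whether the same exchange of bromo for iodo elsewhere on the ring would give a step of similar size and direction, or whether this step is specific to this position.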